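Swapping bromo for chloro on a shared core

The compounds below may be only part of what the source reports. "The series", "measured", "known", "first", "only" and "open" are said of these compounds alone.

Of the compounds shown here, three have so far been measured in a functional assay on MCF7 cells (Homo sapiens) for inhibition, read by MTT assay, with a stated time of 48 h; on this read-out higher numbers stand for weaker inhibition and lower numbers for stronger inhibition. Compound 1 `O=C(C=CNc1cc(-c2ccccc2)nn1-c1ccccc1)c1cccs1` gives 15400 nM, compound 2 `O=C(C=CNc1cc(-c2ccccc2)nn1-c1ccccc1)c1ccccc1` gives 9650 nM, and compound 3 `Brc1ccc(-c2ccnc3c2c(-c2ccccc2)nn3-c2ccccc2)cc1` gives 13300 nM. Compound 3 stands second highest of the three numbers, but its gaps to compound 1 and to compound 2 are both within the scatter, so no order among them can be read. Compound 4 `Clc1ccc(-c2ccnc3c2c(-c2ccccc2)nn3-c2ccccc2)cc1` differs from compound 3 by chloro in place of bromo on an aromatic carbon. Among the compounds with values here, the one measured step, a 1.6-fold lower number from compound 1 to compound 2 (0.20 log units; within the scatter), concerns a different change on a different core and does not bear on this halogen swap. With nothing to point either way, no step beyond the scatter is expected. Compound 4 is therefore estimated at 14000 nM, within a range from 7000 nM to 28000 nM, which means an expected step of a 1.1-fold higher number from compound 3 to compound 4 (0.02 log units; within the scatter).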

Compound 4, half-maximal inhibitory concentration: 61100 nM
Estimate against measurement, compound 4: 4.4-fold (0.64 log units) below; measured number outside the range, above it.
By their numbers in this assay, from the lowest: compounds 2, 3 and 1 (each within the scatter of the next); then compound 4.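

Within the data shown here, this swap gives the first step beyond the scatter in this assay (a 4.6-fold higher number from compound 3 to compound 4 (0.66 log units; beyond the scatter)), whereas the only earlier step stayed within it. On this shared core, the halogen on the aromatic carbon therefore matters: going from 4-bromophenyl to 4-chlorophenyl, one atom for another, brings clearly weaker inhibition. Nothing available explains this difference.

From the compounds shown here alone, whether fluoro, methoxy or an amine at this place would match compound 3 or fall further away remains open. With only two halogens compared here, no trend across this position can be drawn.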